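The compounds below may be only part of what the source reports. "The series", "measured", "known", "first", "only" and "open" are said of these compounds alone.

Compound 2 `CCCN(CC[C@H]1CC[C@H](NS(=O)(=O)c2cccc(C)c2)CC1)[C@H]1CCc2nc(N)sc2C1` and compound 1 `CCCN(CC[C@H]1CC[C@H](NC(=O)/C=C/c2cccc(Cl)c2)CC1)[C@H]1CCc2nc(N)sc2C1` share one core and differ only in the group on the amine nitrogen. In an assay on brain for displacement of a labelled ligand from D(3) dopamine receptor (Rattus norvegicus) (on this read-out lower numbers stand for stronger inhibition and higher numbers for weaker inhibition), compound 1 gives 1.2 nM, and in this assay compound 2 gives 0.89 nM. The step of a 1.3-fold lower number from compound 1 to compound 2 (0.13 log units; within the scatter) is the only one measured, and it lies within the scatter, so the two numbers are best read as equal. Compound 3 `CCCN(CC[C@H]1CC[C@H](NS(=O)(=O)c2ccc(Cl)nc2)CC1)[C@H]1CCc2nc(N)sc2C1` is the next member of this small set. The change from compound 2 to compound 3 is 6-chloropyridin-3-yl in place of 3-methylphenyl on a sulfonyl sulfur. Among the measured compounds shown here, no measured step touches this part of the molecule, so the only guide is that exchanging the whole group on the amine nitrogen, from compound 1 to compound 2, moved the number little. On that basis compound 3 is expected to stay close to compound 2, with a step of about a 1.7-fold higher number from compound 2 to compound 3 (0.23 log units; within the scatter), which is no change beyond the scatter. The estimate for compound 3 in this assay is 1.5 nM, within a range from 0.5 nM to 5 nM.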

Compound 3, inhibition constant: 0.63 nM
Compound 3: middle estimate off by 2.4-fold (0.38 log units), on the high side, and the stated range covers the measured number.
By their numbers in this assay, from the lowest: compounds 3, 2 and 1 (each within the scatter of the next).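

On the sulfonyl sulfur, a ring of carbon only with its methyl can give way to a ring holding a nitrogen and a chlorine: in this assay, the exchange of 3-methylphenyl for 6-chloropyridin-3-yl gives a 1.4-fold lower number from compound 2 to compound 3 (0.15 log units; within the scatter), so the two numbers read as equal. A second sulfonyl group also fails to separate from the amide of compound 1, with a 1.9-fold lower number from compound 1 to compound 3 (0.28 log units; within the scatter). No measurement here explains why these different groups read alike.

From the compounds shown here alone, the chlorine and the ring nitrogen enter together, so what each contributes alone stays unknown. All three groups shown carry an aromatic ring, leaving open whether the number would hold with methylsulfonyl, which has no ring, or with a carboxylic acid or an amine on the ring.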